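Shortening the side chain and adding a triple bond

A few compounds are considered here, and "the series" means these few. Any claim that something is new, unique, unknown or untested is made for them only; others in the source may bear on it.

Compound 1, `CCCCCCCc1c(C)[nH]c2cc(OC)c(Cl)cc2c1=O`, carries a heptyl chain on its core. In a physicochemical assay for lipophilicity, at pH 7.4 (a higher number here means a more lipophilic compound, a lower number a more polar compound), compound 1 gives only a limit, < 3.83, so its true value is not known as a number. Compound 2, `CCCCCCCCCc1c(C)[nH]c2cc(OC)c(Cl)cc2c1=O`, differs from compound 1 by ethyl in place of hydrogen on a saturated chain carbon, seven bonds along the chain from an aromatic carbon, and in this assay compound 2 gives 4.74. Among the measured compounds shown here, the step of a number at least 0.91 log units higher from compound 1 to compound 2 (beyond the scatter) therefore shows that lengthening the chain raised the distribution coefficient; the one piece of evidence on it is the limit of < 3.83 in this assay, at which 1 of the 2 values shown sits.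

Compound 3, `CCCCC#Cc1c(C)[nH]c2cc(OC)c(Cl)cc2c1=O`, is not yet measured. It differs from compound 1 by hex-1-yn-1-yl in place of heptyl on an aromatic carbon. The chain entering has one carbon fewer than the chain leaving, and carries a triple bond. For the measured compounds named here, since the only measured step went upward with a longer chain, the opposite direction is expected here, though the size is uncertain. For compound 3 the distribution coefficient is estimated at 3, between 2.4 and 3.6. That estimate means an expected step that the limit leaves unreadable from compound 1 to compound 3.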

Compound 3, distribution coefficient: 2.45
The estimate for compound 3 lay 0.55 log units above the measured number, and the stated range covers the measured number.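

No new step can be read from compound 3's result: the change from compound 1 to compound 3 stays unreadable, because compound 1 has only a limit in this assay, not a number: the limit of < 3.83 in this assay, at which 1 of the 3 values shown sits. The compounds shown leave open how far, and in which direction, replacing heptyl with hex-1-yn-1-yl moves the distribution coefficient.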